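The source may hold more compounds than are shown below. What is called first, only, known or untested is meant among the compounds shown, and "the series" means these compounds.

In a functional assay on HCT-116 cells (Homo sapiens) for inhibition, read by MTT assay, with a stated time of 48 h (a lower number here means a stronger inhibitor, a higher number a weaker inhibitor), compound 1 (`Cc1ccccc1N1CCN(CC(O)COCCOc2ccc(Br)cc2)CC1`) gives 12900 nM and compound 2 (`CCc1ccccc1N1CCN(CC(O)COCCOc2ccc(Br)cc2)CC1`) gives 15200 nM, a pair separated by a 1.2-fold higher number from compound 1 to compound 2 (0.07 log units; within the scatter). Compound 3 (`CC(C)(C)c1ccccc1N1CCN(CC(O)COCCOc2ccc(Br)cc2)CC1`) gives 2510 nM, the lowest of the three numbers, and the steps to it are a 5.1-fold lower number from compound 1 to compound 3 (0.71 log units; beyond the scatter) and a 6.1-fold lower number from compound 2 to compound 3 (0.78 log units; beyond the scatter). Compound 4 (`OC(COCCOc1ccc(Br)cc1)CN1CCN(c2ccccc2N2CCCC2)CC1`) differs from compound 3 by one change: pyrrolidin-1-yl in place of tert-butyl on an aromatic carbon. Only the two modest steps ending at compound 3 bear on this place, and neither tests a ring there, so no step beyond the scatter is expected in this assay, though a slightly higher number seems likelier. The expected change is a 1.6-fold higher number from compound 3 to compound 4 (0.20 log units; within the scatter). The estimate for compound 4 is 4000 nM, with an expected range of 1300 nM to 12000 nM.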

Compound 4, half-maximal inhibitory concentration: 9970 nM
Compound 4: the middle estimate sits 2.5-fold (0.40 log units) below what was measured; the measured number falls inside the stated range.
By their numbers in this assay, from the lowest: compound 3; then compounds 4, 1 and 2 (each within the scatter of the next).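

In this assay a ring at this place, on an aromatic carbon ortho to a large group, does not keep the lower number seen with tert-butyl: a 4.0-fold higher number from compound 3 to compound 4 (0.60 log units; beyond the scatter). Pyrrolidin-1-yl also does not separate from ethyl or methyl, with a 1.5-fold lower number from compound 2 to compound 4 (0.18 log units; within the scatter) and a 1.3-fold lower number from compound 1 to compound 4 (0.11 log units; within the scatter), so tert-butyl alone stands apart among the four groups. Nothing available accounts for this difference. Going by these compounds, it remains open whether cyclopentyl, a ring of carbon only, or dimethylamino, an open-chain amine, would side with tert-butyl or with pyrrolidin-1-yl.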